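Adding a methylthioethyl side chain to a glycine ester

A few compounds are considered here, and "the series" means these few. Any claim that something is new, unique, unknown or untested is made for them only; others in the source may bear on it.

Measured so far:
compound 1 `O=C(CN(c1ncnc2c1ncn2C1CCCCO1)C1CC1)NCC(=O)OCc1ccccc1` gives 25.9%
compound 2 `O=C(OCc1ccccc1)[C@@H]1CCCN1C(=O)CN(c1nc(Cl)nc2[nH]cnc12)C1CC1` gives 43.3%

Both numbers come from a functional assay on the whole organism (Tail, strain ICR) with Mus musculus as the target, in the tail flick test, with a stated time of 90 min, at a dose of 25 umol/kg by the oral route; a higher number here means a stronger effect of the compound at the dose given, a lower number a weaker effect. Compound 1 stands lowest of the two, with compound 2 higher by a gap beyond the usual scatter. The two differ in several places, so their values are simply compared, not explained.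

Compound 3 `CSCC[C@H](NC(=O)CN(c1ncnc2c1ncn2C1CCCCO1)C1CC1)C(=O)OCc1ccccc1` is built from compound 1 by one change: 2-(methylsulfanyl)ethyl in place of hydrogen on a saturated chain carbon bound to an amide-type nitrogen and a carbonyl carbon. Within the data shown here, no comparable single step has been measured here. A modest rise is expected, so the step of a number 9.1 percentage points higher from compound 1 to compound 3 (within the scatter) is an estimate only. Compound 3 is expected to give 35%, between 15% and 55%.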

Compound 3, a percentage reported as activity, at one dose (the size of the read-out at that dose, not a potency): 42.7%
For compound 3 the middle estimate is 7.7 percentage points below the measured one; the measured number falls inside the stated range.
By their numbers in this assay, from the lowest: compound 1; then compounds 3 and 2 (each within the scatter of the next).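

Putting 2-(methylsulfanyl)ethyl in place of hydrogen on a saturated chain carbon bound to an amide-type nitrogen and a carbonyl carbon gives a number 16.8 percentage points higher from compound 1 to compound 3 (beyond the scatter) in this assay. Among these compounds, this is the first single change that can be read here, and it shows that this carbon can carry a side chain without any loss of effect at the dose given. No measurement here bears on the reason for this step. Still open, on these data alone, is whether the sulfur matters or the chain alone is enough: a plain butyl chain at this carbon would separate the two, and a methyl group would show whether a shorter chain does the same.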